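This account rests on a few compounds, and the source may have more. Where it says the series, first, only, none or still open, it means among the compounds named here.

Compound 1 `CNC(=O)c1cccc(Cn2nc(C)c(NC(=O)c3ccc(COc4cccc(C)c4)cc3)c2C)c1`: 6200 nM
Compound 2 `CNC(=O)c1cccc(Cn2nc(C)c(NC(=O)c3ccc(COc4cccc(C(F)(F)F)c4)cc3)c2C)c1`: 2300 nM

Of the compounds shown here, two have been measured in a functional assay on MIA PaCa-2 cells (Homo sapiens) for antiproliferative activity, read by MTT assay, with a stated time of 72 h; a lower number here means that less compound is needed, a higher number that more compound is needed for the effect. Compound 1 gives 6200 nM, and compound 2 gives 2300 nM, the lower of the two numbers. Going by the values given here, the single recorded step, a 2.7-fold lower number from compound 1 to compound 2 (0.43 log units; beyond the scatter), is modest and lies beyond the scatter. Compound 3 `CNC(=O)c1cccc(Cn2nc(C)c(NC(=O)c3ccc(COc4ccc(C(F)(F)F)cc4)cc3)c2C)c1` is the next compound and differs from compound 2 in only one way: 4-(trifluoromethyl)phenyl in place of 3-(trifluoromethyl)phenyl on an oxygen on a saturated carbon. Among the compounds with values here, no measured step changes where the trifluoromethyl group sits on its ring; the one step available, a 2.7-fold lower number from compound 1 to compound 2 (0.43 log units; beyond the scatter), replaced the group itself rather than moving it, so it offers no direct guide to the present change. On this basis no step beyond the scatter is expected. Compound 3 is therefore estimated at 2300 nM in this assay, with a range from 1000 nM to 5500 nM. The step expected is no change at the digits printed from compound 2 to compound 3 (within the scatter).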

Compound 3, half-maximal effective concentration: 800 nM
For compound 3 the middle estimate is 2.9-fold (0.46 log units) above the measured one; measured number below the stated range.
By their numbers in this assay, from the lowest: compound 3; then compound 2; then compound 1.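

In this assay, moving the trifluoromethyl group from 3-(trifluoromethyl)phenyl to 4-(trifluoromethyl)phenyl gives a 2.9-fold lower number from compound 2 to compound 3 (0.46 log units; beyond the scatter) and thus shows that, with the same atoms present, where the group sits on its ring changes the number. Changing both the group and its place, with 4-(trifluoromethyl)phenyl in place of 3-methylphenyl, gives a 7.8-fold lower number from compound 1 to compound 3 (0.89 log units; beyond the scatter) and is the largest step among the three compounds shown. No measurement shown accounts for this effect of place.

The compounds shown leave open whether 4-methylphenyl would show the same effect of place as the trifluoromethyl pair. They also leave open how a nitrile, a methoxy group or a chlorine atom would read in place of the trifluoromethyl group of 4-(trifluoromethyl)phenyl.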